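The source may report more compounds than this note shows. Statements on the series, on what has been measured and on what is new or still open speak of the compounds shown alone.

Compound 1 `COc1cc2ncnc(NCc3cccc(NC(=O)Nc4ccccc4C)c3)c2cc1OC` and compound 2 `COc1ccccc1NC(=O)Nc1cccc(CNc2ncnc3cc(OC)c(OC)cc23)c1` share a core and differ only on the outer aromatic ring of the urea, where a methyl in compound 1 is exchanged for a methoxy in compound 2. In a functional assay on A549 cells (Homo sapiens) for antiproliferative activity, read by MTT assay (on this read-out higher numbers stand for weaker inhibition and lower numbers for stronger inhibition), compound 1 gives 21400 nM, and compound 2 gives 15200 nM. The step of a 1.4-fold lower number from compound 1 to compound 2 (0.15 log units; within the scatter) is within the usual scatter, so the two numbers cannot be told apart; compound 2 is simply one of two measured compounds that sit together.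

Compound 3 `COc1cc2ncnc(NCc3cccc(NC(=O)Nc4ccc(C(C)(C)C)cc4)c3)c2cc1OC` has not been measured. It differs from compound 2 by 4-(tert-butyl)phenyl in place of 2-methoxyphenyl on an amide-type nitrogen. Going by the values given here, the only measured step, from compound 1 to compound 2, changed a small group on that same ring and stayed within the scatter; no measured compound carries a 4-(tert-butyl)phenyl, so nothing shows whether that group matters. The expected step of a 1.1-fold higher number from compound 2 to compound 3 (0.02 log units; within the scatter) is therefore none beyond the scatter, with a wide range. Compound 3 is estimated at 16000 nM in this assay, between 5000 nM and 50000 nM.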

Compound 3, half-maximal inhibitory concentration: 5210 nM
For compound 3 the middle estimate is 3.1-fold (0.49 log units) above the measured one; the measured number falls inside the stated range.
By their numbers in this assay, from the lowest: compound 3; then compounds 2 and 1 (each within the scatter of the next).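

The aromatic group on the amide-type nitrogen is a place where the read-out can move. In this assay, 4-(tert-butyl)phenyl in place of 2-methoxyphenyl gives a 2.9-fold lower number from compound 2 to compound 3 (0.47 log units; beyond the scatter), and the same group in place of 2-methylphenyl gives a 4.1-fold lower number from compound 1 to compound 3 (0.61 log units; beyond the scatter). Both steps are modest but lie beyond the scatter, so the lower number is a real difference, which the earlier exchange of methyl for methoxy could not show; even so, this change swaps the substituent and its ring position together, so the compounds cannot separate the contribution of the tert-butyl group from that of its position.

On these data alone, it remains open whether a smaller group such as 4-methylphenyl would give a similar number, or whether an amine or a carboxylic acid in place of the tert-butyl group would keep the lower number or lose it. Nothing available here explains why the number falls with this group, and the step stands as an observation only.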